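A few compounds are considered here, and "the series" means these few. Any claim that something is new, unique, unknown or untested is made for them only; others in the source may bear on it.

Compound 1, `c1ccc2nc(COc3ccc(CCc4nnn[nH]4)cc3)ccc2c1`: 160 nM
Compound 2, `O=C(CCCOc1ccc(OCc2ccc3ccccc3n2)cc1)NS(=O)(=O)c1ccccc1`: 31 nM

Both compounds were tested in an assay on isolated protein for binding affinity to cysteinyl leukotriene receptor 1 (Cavia porcellus); a lower number here means a stronger inhibitor, a higher number a weaker inhibitor. Compound 2 stands with the lowest of the two numbers; compound 1 gives 160 nM, a higher number that lies beyond the usual scatter. Compound 3, `CCOC(=O)CCCOc1ccc(OCc2ccc3ccccc3n2)cc1`, is not yet measured. It differs from compound 2 in one place: ethoxy in place of (phenylsulfonyl)amino on a carbonyl carbon. Going by the values given here, no measured pair shows this change, so its effect is unknown. A weaker binder is expected, the step from compound 2 to compound 3 estimated at a 13-fold higher number from compound 2 to compound 3 (1.11 log units; beyond the scatter). Compound 3 is thus estimated at 400 nM, within a range from 100 nM to 2000 nM.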

Compound 3, inhibition constant: 500 nM
Estimate against measurement, compound 3: 1.3-fold (0.10 log units) below; measured number inside the range.
By their numbers in this assay, from the lowest: compound 2; then compound 1; then compound 3.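

In this assay, ethoxy in place of (phenylsulfonyl)amino on a carbonyl carbon gives a large loss of binding (a 16-fold higher number from compound 2 to compound 3 (1.21 log units; beyond the scatter)), so this position responds strongly to the group it carries. The change with the tetrazole-bearing compound is smaller (a 3.1-fold higher number from compound 1 to compound 3 (0.49 log units; beyond the scatter)), with 3-(ethoxycarbonyl)propoxy in place of 2-(1H-tetrazol-5-yl)ethyl on an aromatic carbon. No measurement here explains either step.

Going by these compounds, the benzene ring, the sulfonyl and the hydrogen-bond donor all leave together, so their separate contributions stay unknown. A carboxylic acid or a methylsulfonylamino group on that carbonyl carbon would help to separate them.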